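Notes on the side-chain change from compound 1 to compound 4

The source may report more compounds than this note shows. Statements on the series, on what has been measured and on what is new or still open speak of the compounds shown alone.

Compound 1 `C#CCOC(=O)C1=C(N)Oc2ccc(-c3cc(OC)cc(OC)c3)cc2C1CC(=O)CCC` is the starting point of this step. Among the measured compounds shown here, in a functional assay on HL-60 cells (Homo sapiens) for inhibition, with a stated time of 48 h (on this read-out lower numbers stand for stronger inhibition and higher numbers for weaker inhibition), compound 1 gives 6900 nM, the second highest of the three numbers measured so far. Compound 2 `CCOC(=O)CC1C(C(=O)OCC)=C(N)Oc2ccc(-c3cc(OC)cc(OC)c3)cc21` gives 5400 nM in this assay, a number within the scatter of compound 1. Compound 3 `CCOC(=O)C1=C(N)Oc2ccc(-c3cc(OC)cc(OC)c3)cc2C1CC(=O)c1ccccc1` gives 109000 nM, far beyond compound 1 toward weaker inhibition.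

The change to compound 4 `C#CCOC(=O)C1=C(N)Oc2ccc(-c3cc(OC)cc(OC)c3)cc2C1CC(O)c1ccccc1` is hydroxy(phenyl)methyl in place of propylcarbonyl on a saturated chain carbon bound to a saturated ring carbon.

For the measured compounds named here, one measured step bears on it: a 20-fold higher number from compound 2 to compound 3 (1.31 log units; beyond the scatter). That step also brings a phenyl onto the side chain, there on a carbonyl carbon, and the number moves strongly toward weaker inhibition. Going by the values given here, compound 1 and compound 3 differ in two places and no single step connects them; their values alone show compound 3 well above compound 1. Among the compounds with values here, the change to compound 4 places the phenyl within hydroxy(phenyl)methyl rather than on a carbonyl, and no measured pair tests a hydroxyl at this position, so the expectation rests on the entering phenyl alone. Compound 4 is therefore expected to move toward weaker inhibition, a 4.3-fold higher number from compound 1 to compound 4 (0.64 log units; beyond the scatter), with the estimate for compound 4 at 30000 nM in a range of 8000 nM to 120000 nM.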

Compound 4, half-maximal inhibitory concentration: 100000 nM
The estimate for compound 4 lay 3.3-fold (0.52 log units) below the measured number; the measured number falls inside the stated range.
By their numbers in this assay, from the lowest: compounds 2 and 1 (each within the scatter of the next); then compounds 4 and 3 (each within the scatter of the next).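

In this assay the side-chain change gives a 14-fold higher number from compound 1 to compound 4 (1.16 log units; beyond the scatter) and so shows that a large move toward weaker inhibition also occurs on the ester of compound 1, not only on the ester of compound 2. Together with a 20-fold higher number from compound 2 to compound 3 (1.31 log units; beyond the scatter) it makes two large steps in the same direction where a phenyl enters the side chain, with no compound shown going against that reading, and the rise does not depend on the phenyl sitting on a carbonyl carbon, since in compound 4 it sits on a carbon bearing a hydroxyl. No measurement available here gives a reason for either step.

From the compounds shown here alone, the change to compound 4 swaps the carbonyl for a hydroxyl and brings in the phenyl at once, so the share of each in the step stays open; a hydroxybutyl group on a saturated chain carbon bound to a saturated ring carbon would keep the hydroxyl without the phenyl, and a benzyl group would keep the phenyl without the hydroxyl. Going by these compounds, whether an amine or a carboxylic acid in this place would hold the number near that of compound 1 also stays open.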